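Pyrrolidin-1-yl for methylsulfanyl on the shared core

The source may report more compounds than this note shows. Statements on the series, on what has been measured and on what is new or still open speak of the compounds shown alone.

Of the compounds shown here, three have been read in an ADME assay on Vero cells (Chlorocebus sabaeus) for cytotoxicity, read by CellTiter-Glo, with a stated time of 72 h; a higher number here means that more compound is tolerated, a lower number that less compound is tolerated. Among the measured compounds shown here, compound 1 `COC(=O)/C=C/n1ccnc1[N+](=O)[O-]` is the only one with a number, at 16 ug/mL. Compound 2 `CSc1c(C)[n+]([O-])c2ccccc2[n+]1[O-]` gives only a limit, > 16 ug/mL. Compound 3 `COCCNC(=O)c1ccc2c(c1)[n+]([O-])c(C(C)=O)c(C)[n+]2[O-]` likewise gives only a limit, > 16 ug/mL. The position of compound 2 is therefore known only as a limit, and it shares that limit with compound 3: the limit of > 16 ug/mL in this assay, at which 2 of the 3 values shown sit.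

Compound 4 `Cc1c(N2CCCC2)[n+]([O-])c2ccccc2[n+]1[O-]` has pyrrolidin-1-yl in place of methylsulfanyl on an aromatic carbon, next to the ring nitrogen (pyrrolidin-1-yl in place of methylsulfanyl on an aromatic carbon). For the measured compounds named here, no measured pair shows a change of this kind, so any expectation is loose. Little or no move beyond the scatter is expected, and any move is expected to be towards less compound tolerated. The expected change is an at least 1.1-fold lower number from compound 2 to compound 4 (0.05 log units; that floor lies within the scatter). For compound 4 the estimate in this assay is 14 ug/mL, with an expected range of 5 ug/mL to 16 ug/mL.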

Compound 4, half-maximal cytotoxic concentration: > 16 ug/mL
Compound 4 was reported as a limit (the forecaster's own chance of this, stated with the estimate: 55%); middle value at least 1.1-fold (0.05 log units) away from the limit.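

No step can be read between compound 2 and compound 4, since both are reported only as limits: the limit of > 16 ug/mL in this assay, at which 3 of the 4 values shown sit.

The compounds shown leave open whether pyrrolidin-1-yl in place of methylsulfanyl on an aromatic carbon changes the tolerated concentration at all, and in which direction.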